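Aryl swap on the shared core: compound 2 to compound 3

The source may hold more compounds than are shown below. What is called first, only, known or untested is meant among the compounds shown, and "the series" means these compounds.

Compound 1 `COc1cc(-c2ccnc3cc(-c4ccc(C)cc4)nn23)cc(OC)c1OC` gives 21 nM in a functional assay on HeLa cells (Homo sapiens) for inhibition, read by CCK-8 assay, with a stated time of 48 h; a higher number here means a weaker inhibitor, a lower number a stronger inhibitor. Compound 2 `COc1cc(-c2ccnc3cc(-c4ccc5ccn(C)c5c4)nn23)cc(OC)c1OC` gives 187 nM in this assay, the highest of the two numbers, and the step of an 8.9-fold higher number from compound 1 to compound 2 (0.95 log units; beyond the scatter) lies beyond the scatter. Compound 3 `COc1cc(-c2ccnc3cc(-c4ccccc4)nn23)cc(OC)c1OC` carries the change (phenyl in place of 1-methyl-1H-indol-6-yl on an aromatic carbon). For the measured compounds named here, the one step that bears on it is an 8.9-fold higher number from compound 1 to compound 2 (0.95 log units; beyond the scatter); the entering phenyl has the single six-membered carbon ring that the 4-methylphenyl of compound 1 also has, so a downward step in this assay of about a 6.2-fold lower number from compound 2 to compound 3 (0.79 log units; beyond the scatter) is expected, back toward compound 1. Compound 3 is estimated at 30 nM, within 10 nM to 90 nM.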

Compound 3, half-maximal inhibitory concentration: 458 nM
Compound 3: middle estimate off by 15-fold (1.18 log units), on the low side; measured number outside the range, above it.
By their numbers in this assay, from the lowest: compound 1; then compound 2; then compound 3.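

At this position a single six-membered carbon ring does not by itself hold the low number: the swap to phenyl gives a 2.4-fold higher number from compound 2 to compound 3 (0.39 log units; beyond the scatter) in this assay and removing the methyl gives a 22-fold higher number from compound 1 to compound 3 (1.34 log units; beyond the scatter) as the larger step. Among these three compounds the 1-methyl-1H-indol-6-yl of compound 2 therefore falls between the 4-methylphenyl and the phenyl. Nothing at hand explains this order.

Open, on these data alone, is whether an ethyl, a methoxy or an amine in place of that methyl keeps the number of compound 1. Also open, as far as these compounds go, is how a thiophene ring at this position would compare.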